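A bromo group in place of the compound 2 ester

The source may report more compounds than this note shows. Statements on the series, on what has been measured and on what is new or still open speak of the compounds shown alone.

In a functional assay on SW-620 cells (Homo sapiens) for cytotoxicity (a lower number here means a stronger inhibitor of growth, a higher number a weaker inhibitor of growth), compound 1 `COc1ccc(C2=C(c3ccc(SC)cc3)CC3CCCN3C2=O)cc1O` gives 20000 nM. Compound 2 `COc1ccc(C2=C(c3ccc(SC)cc3)CC3CCCN3C2=O)cc1OC(=O)CNC(=O)OC(C)(C)C` gives 20000 nM, level with compound 1 at the digits available. The next analogue is compound 3 `COc1ccc(C2=C(c3ccc(SC)cc3)CC3CCCN3C2=O)cc1Br`, with the change (one bromine atom in place of a group of 12 heavy atoms (7 carbon, 1 nitrogen, 4 oxygen; no ring), on an aromatic carbon); the bromo group sits ortho to a methoxy group and meta to a large group, and the rest of the molecule is unchanged.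

Among the compounds with values here, only one measured step bears on this place: no change at the digits printed from compound 1 to compound 2 (within the scatter). That step is no change within the scatter, even though a large group was added. Within the data shown here, no bromo analogue or other halogen has been measured, so this rests on a single pair. No step beyond the scatter is expected, and the estimated step is a 1.3-fold lower number from compound 2 to compound 3 (0.10 log units; within the scatter). For compound 3 the expected value is 16000 nM, with an estimated range of 6000 nM to 40000 nM.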

Compound 3, concentration for 50% growth inhibition: 5000 nM
Compound 3: middle estimate off by 3.2-fold (0.51 log units), on the high side; the measured number lies below the stated range.
By their numbers in this assay, from the lowest: compound 3; then compounds 1 and 2 (each within the scatter of the next).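

In this assay, this aromatic carbon proves sensitive to what it carries, which the level pair of hydroxy and the large ester, no change at the digits printed from compound 1 to compound 2 (within the scatter), did not reveal. Bromo in place of hydroxy gives a 4.0-fold lower number from compound 1 to compound 3 (0.60 log units; beyond the scatter), and bromo in place of the ester gives a 4.0-fold lower number from compound 2 to compound 3 (0.60 log units; beyond the scatter), so compound 3 separates from both earlier compounds by a step beyond the scatter. No measurement here gives a cause for that step.

Going by these compounds, both groups that leave are joined to the ring through oxygen, so it stays open whether the lower number belongs to bromo itself or to the absence of that oxygen; a chloro, methyl or amino group at this carbon would separate the two. On these data alone, whether the step survives a change to the methoxy group also stays open.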